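Estimating a chloro-trifluoromethyl analogue from three measured compounds

The compounds below may be only part of what the source reports. "The series", "measured", "known", "first", "only" and "open" are said of these compounds alone.

Compound 1 `Cn1ccc2c(Oc3ccc(NC(=O)c4cn(-c5ccc(Cl)cc5)c5ccccc5c4=O)cc3F)ccnc21`: in a functional assay on A549 cells (Homo sapiens) for inhibition, read by MTT assay, with a stated time of 72 h (on this read-out higher numbers stand for weaker inhibition and lower numbers for stronger inhibition), compound 1 gives 250 nM.
Compound 2 `Cn1ccc2c(Oc3ccc(NC(=O)c4cn(-c5ccc(Br)cc5)c5ccccc5c4=O)cc3F)ccnc21`: in this assay compound 2 gives 1390 nM.
Compound 3 `Cn1ccc2c(Oc3ccc(NC(=O)c4cn(-c5ccc(Br)cc5F)c5ccccc5c4=O)cc3F)ccnc21`: in this assay compound 3 gives 1520 nM.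

Compound 3 stands at the highest number of the three. Its nearest neighbour is compound 2, with a gap within the scatter, so the two cannot be ordered; the only real separation is from compound 1, as a 6.1-fold higher number from compound 1 to compound 3 (0.78 log units; beyond the scatter) shows.

Compound 4 `Cn1ccc2c(Oc3ccc(NC(=O)c4cn(-c5ccc(C(F)(F)F)cc5Cl)c5ccccc5c4=O)cc3F)ccnc21` differs from compound 3 in one place: 2-chloro-4-(trifluoromethyl)phenyl in place of 4-bromo-2-fluorophenyl on an aromatic nitrogen.

Among the compounds with values here, two measured steps bear on this. The step of a 5.6-fold higher number from compound 1 to compound 2 (0.75 log units; beyond the scatter) shows that exchanging one halogen for another on this ring moved the number by a modest but real amount. The step of a 1.1-fold higher number from compound 2 to compound 3 (0.04 log units; within the scatter) shows that adding a fluoro to the same ring changed nothing beyond the scatter. Neither step involves a trifluoromethyl or a chloro in the positions now occupied, so the direction of the new change is not indicated by the data, and no step beyond the scatter can be expected with confidence.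

Compound 4 is therefore estimated at 1500 nM, with a range from 400 nM to 6000 nM. The step of a 1.0-fold lower number from compound 3 to compound 4 (0.01 log units; within the scatter) is expected to stay within the scatter.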

Compound 4, half-maximal inhibitory concentration: 2050 nM
Estimate against measurement, compound 4: 1.4-fold (0.14 log units) below; measured number inside the range.
By their numbers in this assay, from the lowest: compound 1; then compounds 2, 3 and 4 (each within the scatter of the next).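

In this assay, the new group on the aromatic nitrogen carries 11 heavy atoms against 8 in the 4-bromo-2-fluorophenyl it replaces, yet the exchange gives a 1.3-fold higher number from compound 3 to compound 4 (0.13 log units; within the scatter) and the exchange from 4-bromophenyl gives a 1.5-fold higher number from compound 2 to compound 4 (0.17 log units; within the scatter), so neither the larger group nor the trifluoromethyl in it separates compound 4 from these two neighbours. Within the data shown here, the earlier compounds had varied only single halogens on this ring, and compound 4 now shows that a more extensive change here can leave the number where the bromo compounds stand, while an 8.2-fold higher number from compound 1 to compound 4 (0.91 log units; beyond the scatter) confirms that compound 1, with its 4-chlorophenyl, remains the only compound set apart from the others, with the lowest number of the four. No measurement offered here accounts for this picture.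

The compounds shown leave open how the chloro and the trifluoromethyl of compound 4 each contribute, as neither is varied alone in this group. They also leave open whether a methoxy, an amine or a carboxylic acid on this phenyl ring would stay with compounds 2, 3 and 4 or come closer to compound 1.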